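The source may hold more compounds than are shown below. What is called first, only, known or untested is meant among the compounds shown, and "the series" means these compounds.

Working notes on the series sharing the core of compound 1 (`O=C1Nc2c(C(F)(F)F)cccc2C1(c1ccc(O)cc1)c1ccc(OC(F)(F)F)cc1`). In a functional assay on MCF7 cells (Homo sapiens) for inhibition, read by resazurin assay, with a stated time of 24 h (on this read-out lower numbers stand for stronger inhibition and higher numbers for weaker inhibition), compound 1 gives 20 nM. Compound 2 (`O=C1Nc2c(C(F)(F)F)cccc2C1(c1ccc(OC(F)(F)F)cc1)c1cc(F)c(O)c(F)c1`) reads > 1000 nM, which is a limit of the assay and not a number. Compound 3 (`O=C1Nc2c(C(F)(F)F)cccc2C1(c1ccc(OC(F)(F)F)cc1)c1c(F)cc(O)cc1F`) gives 549 nM, the higher of the two actual numbers in hand, with a 27-fold higher number from compound 1 to compound 3 (1.44 log units; beyond the scatter).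

Next is compound 4 (`O=C1Nc2c(C(F)(F)F)cccc2C1(c1ccc(OC(F)(F)F)cc1)c1ccc(OC(F)(F)F)cc1`), reached through 4-(trifluoromethoxy)phenyl in place of 2,6-difluoro-4-hydroxyphenyl on a saturated ring carbon. Among the compounds with values here, two large measured steps bear on this carbon: the one to compound 3 already given, and an at least 50-fold higher number from compound 1 to compound 2 (1.69 log units; beyond the scatter). Between the two fluorinated compounds lies an at least 1.8-fold lower number from compound 2 to compound 3 (0.26 log units; that floor lies within the scatter). Within the data shown here, all three measured compounds keep a hydroxyphenyl group and compound 4 has none, so no measured step matches this change directly. The nearest guide is that both departures from the 4-hydroxyphenyl of compound 1 raised the number.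

A further, more moderate rise in this assay is therefore expected, and a report as a limit is quite possible. The estimated move is a 2.7-fold higher number from compound 3 to compound 4 (0.44 log units; beyond the scatter). For compound 4 the expected value is 1500 nM, with an estimated range of 400 nM to 10000 nM.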

Compound 4, half-maximal inhibitory concentration: > 1000 nM
Compound 4 ended at the assay's limit; the forecaster's own chance of this, stated with the estimate: 60%; the middle value does not contradict the limit.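

In this assay compound 4 gives > 1000 nM, a limit of the assay and not a number. Placing trifluoromethyl on the oxygen of the 4-hydroxyphenyl group gives an at least 50-fold higher number from compound 1 to compound 4 (1.69 log units; beyond the scatter), the first measured change on this saturated ring carbon that leaves no hydroxyl on either aryl group, and all three departures from the 4-hydroxyphenyl of compound 1 now raise the number, with no compound shown going against that. The exchange of 2,6-difluoro-4-hydroxyphenyl for 4-(trifluoromethoxy)phenyl gives an at least 1.8-fold higher number from compound 3 to compound 4 (0.26 log units; that floor lies within the scatter), a floor that does not by itself separate the two compounds, and the step between compound 2 and compound 4 cannot be read, so the upper end of the series stays unranked: the limit of > 1000 nM in this assay, at which 2 of the 4 values shown sit.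

Still open, from the compounds shown here alone, is whether any group other than the hydroxyl is tolerated on the phenyl ring at this carbon, since a methoxy group, an amine or a carboxylic acid would separate the role of the oxygen from that of its hydrogen. Going by these compounds, how far compound 2 and compound 4 lie past the limit also remains unknown, so the true size of the loss on capping the hydroxyl is open.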